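The source may report more compounds than this note shows. Statements on the series, on what has been measured and on what is new or still open speak of the compounds shown alone.

The account concerns three measured compounds and one that awaits a number. Compound 1 `O=C(Nc1ccccc1OC(F)(F)F)Nc1n[nH]c2ccccc12` gives 72500 nM in a functional assay on SN12C cells (Homo sapiens) for inhibition, read by sulforhodamine B assay, with a stated time of 48 h; a higher number here means a weaker inhibitor of growth, a lower number a stronger inhibitor of growth. Compound 2 `Nc1nn(C(=O)Nc2ccc(Cc3ccccc3)cc2)c2ccccc12` gives 12900 nM in this assay, the lowest of the two numbers shown, with compound 1 the nearest at a gap that lies beyond the scatter of repeated runs. For the measured compounds named here, compound 3 `COc1ccc(NC(=O)Nc2n[nH]c3ccccc23)cc1` is reported in this assay only as the limit > 100000 nM, not as a number; this matches (the limit of > 100000 nM in this assay, at which 1 of the 3 values shown sits), and it leaves no step to compound 2 that could be counted.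

Compound 4 `CCCCOc1ccc(NC(=O)n2nc(N)c3ccccc32)cc1` is the one still to be measured. It differs from compound 2 by a single change, butoxy in place of benzyl on an aromatic carbon — butoxy in place of benzyl on an aromatic carbon, para to a large group. Going by the values given here, no measured pair shows a change of this kind, so the size of the step from compound 2 to compound 4 rests on expectation alone. A modest weakening in this assay is expected, on the order of a 2.3-fold higher number from compound 2 to compound 4 (0.37 log units; beyond the scatter), though a result within the scatter would not surprise. Compound 4 is therefore estimated at 30000 nM in this assay, with a plausible range from 10000 nM to 100000 nM.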

Compound 4, concentration for 50% growth inhibition: 23100 nM
Compound 4: middle estimate off by 1.3-fold (0.11 log units), on the high side; measured number inside the range.
By their numbers in this assay, from the lowest: compounds 2 and 4 (each within the scatter of the next); then compound 1. At a limit, above all of these: compound 3.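

For the compounds shown here, the exchange of benzyl for butoxy, on an aromatic carbon para to a large group, gives the first step that can be read at this place, and in this assay it amounts to a 1.8-fold higher number from compound 2 to compound 4 (0.25 log units; within the scatter) and no more. This place therefore takes a chain with no ring and with an oxygen in place of benzyl, with no change that can be told from the scatter of repeated runs. Nothing measured among these compounds gives a reason for this step.

On these data alone, what remains open is whether a longer chain, or a chain ending in an amine or a carboxylic acid, would leave the number as little changed at this place. Nor do the compounds show how a phenyl group set directly on this carbon would compare with benzyl or butoxy.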